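The compounds below may be only part of what the source reports. "The series", "measured", "known", "first", "only" and "open" are said of these compounds alone.

All three compounds share one core, with an amino-type nitrogen attached to the aromatic ring and carrying the group that varies. Compound 1 `Cc1ccccc1-c1nnc(N(N)C(C)C)s1` has been tested in a functional assay on the whole organism with Mus musculus as the target, with a stated time of 1 h (a higher number here means that more compound is needed for the effect, a lower number that less compound is needed), and compound 1 gives 49 mg/kg. Compound 2 `Cc1ccccc1-c1nnc(NNC2CCCC2)s1` carries a cyclopentylamino group on that nitrogen. In this assay compound 2 reaches only the limit of the test, > 100 mg/kg, so no exact number is known for it. Compound 2 thus stands at the limit of > 100 mg/kg in this assay, at which 1 of the 2 values shown sits. Compound 3 `Cc1ccccc1-c1nnc(NN(C)C(C)C)s1` has not yet been measured; it differs from compound 2 by isopropyl(methyl)amino in place of cyclopentylamino on a nitrogen on an aromatic ring. Compound 1 gives 49 mg/kg with an isopropyl group in place, and compound 3, which also carries an isopropyl group, is expected to land in a similar region. The step from compound 2 to compound 3 is therefore expected to be an at least 1.4-fold lower number from compound 2 to compound 3 (0.15 log units; that floor lies within the scatter), towards a smaller dose. Compound 3 is expected to give 70 mg/kg, with a range from 30 mg/kg to 160 mg/kg.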

Compound 3, dose for half-maximal effect: > 100 mg/kg
Compound 3 was reported as a limit (the forecaster's own chance of this, stated with the estimate: 35%); middle value at least 1.4-fold (0.15 log units) from the limit.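

Sharing an isopropyl group with compound 1 does not give compound 3 a measurable dose in this assay: compound 3 stands at > 100 mg/kg, which is a limit of the test and not a number. Swapping the whole group on the aromatic carbon gives an at least 2.0-fold higher number from compound 1 to compound 3 (0.30 log units; that floor lies within the scatter), so even this step is not firmly beyond normal variation, while the step between compounds 2 and 3 cannot be read at all. An open-chain group with no hydrogen-bond donor and a ring-bearing group with one now end at the same ceiling: the limit of > 100 mg/kg in this assay, at which 2 of the 3 values shown sit.

Going by these compounds, how far compounds 2 and 3 really lie past that limit remains unknown. Also open, on these data alone, is whether an isopropylamino group, without the methyl, would bring a measurable dose on this nitrogen.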